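The source may hold more compounds than are shown below. What is called first, only, known or untested is meant among the compounds shown, and "the series" means these compounds.

Compound 1, `Cc1ccc(SCc2ccc(C(=O)Nc3ccccc3N)cc2)cc1`: 84%
Compound 2, `CC(C)(C)c1ccc(SCc2ccc(C(=O)Nc3ccccc3N)cc2)cc1`: 60.5%
Compound 3, `Nc1ccccc1NC(=O)/C=C/c1ccc(CSc2ccc(C(F)(F)F)cn2)cc1`: 14.9%

The read-out throughout is a functional assay on HCT-116 cells (Homo sapiens) for inhibition, read by CCK-8 assay, with a stated time of 72 h, tested at 8 uM; on this read-out higher numbers stand for more inhibition of growth at the one concentration tested and lower numbers for less inhibition of growth. Among the three measured compounds, compound 1 stands highest: compound 2 lies a number 23.5 percentage points lower from compound 1 to compound 2 (beyond the scatter), a change made by putting tert-butyl in place of methyl on an aromatic carbon, and compound 3, which differs from it in more than one place, gives a far lower figure with 14.9%.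

The new compound is compound 4, `Nc1ccccc1NC(=O)c1ccc(CSCCc2ccccc2)cc1`. Against compound 1 its change is phenethyl in place of 4-methylphenyl on a sulfur. Among the measured compounds shown here, the only measured step that bears on it is the one from compound 1 to compound 2, where a larger group on the same side of the sulfur cost a number 23.5 percentage points lower from compound 1 to compound 2 (beyond the scatter) in this assay. Compound 4 also carries a longer group on that sulfur, though here the ring itself is moved one chain further out rather than simply enlarged, so the step from compound 2 is only a rough guide. On that basis a modest decrease beyond the scatter is expected, though not a collapse toward compound 3.

Compound 4 is therefore estimated at 65%, within a range of 42% to 84%. This estimate amounts to an expected step of a number 19 percentage points lower from compound 1 to compound 4 (beyond the scatter) from compound 1.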

Compound 4, percent growth inhibition at one concentration: 81.3%
The estimate for compound 4 lay 16.3 percentage points below the measured number; the measured number falls inside the stated range.
By their numbers in this assay, from the lowest: compound 3; then compound 2; then compounds 4 and 1 (each within the scatter of the next).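

In this assay, phenethyl in place of 4-methylphenyl on a sulfur whose other neighbour is a saturated chain carbon gives a number 2.7 percentage points lower from compound 1 to compound 4 (within the scatter) and so leaves no difference that this read-out can resolve. The earlier step, a number 23.5 percentage points lower from compound 1 to compound 2 (beyond the scatter) on exchanging methyl for tert-butyl, had shown only that this end of the molecule does not accept every change; compound 4 shows that the aromatic ring need not be bound directly to the sulfur for compound 4 to match compound 1 at the one concentration tested. Nothing in the data shown accounts for why one of these changes carries a cost beyond the scatter and the other does not.

From the compounds shown here alone, it remains open whether a 3-phenylpropyl group on the sulfur, with a longer chain before the ring, or a cyclohexylmethyl group, with no aromatic ring at all, would hold the figure seen for compound 4. A reading at one concentration also leaves open how compound 1 and compound 4 would compare across a range of concentrations.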